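A few compounds are considered here, and "the series" means these few. Any claim that something is new, unique, unknown or untested is made for them only; others in the source may bear on it.

Compound 3, `CS(=O)(=O)c1c(CCc2ccccc2)c2cc(OCC(=O)Nc3ccccc3)ccc2[nH]c1=O`, carries a phenylethyl chain and a methylsulfonyl group on the shared core, with an anilide at the end of the ether side chain. In an assay on CHO-K1 cells for displacement of a labelled ligand from adenosine receptor A1 (Homo sapiens), with a stated time of 2 h (a higher number here means a weaker inhibitor, a lower number a stronger inhibitor), compound 3 gives 1330 nM. Of the two numbers available, this is the higher one; the lower belongs to compound 1, `CC[C@H](NC(=O)COc1ccc2[nH]c(=O)c(-c3nccs3)c(CCc3ccccc3)c2c1)c1ccccc1`, which in this assay gives 8.6 nM, a gap well beyond the usual scatter. Compound 2, `CS(=O)(=O)c1c(CCc2ccccc2)c2cc(OCC(=O)NCC3CC3)ccc2[nH]c1=O`, has a cyclopropylmethyl amide in place of the anilide and in this assay gives > 10000 nM, which is a limit of the measurement and not a number, as recorded in the limit of > 10000 nM in this assay, at which 1 of the 3 values shown sits.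

Within the data shown here, the one step measured along this side chain runs an at least 7.5-fold lower number from compound 2 to compound 3 (0.87 log units; beyond the scatter). The next compound, compound 4, `CN(Cc1ccc(Cl)c(Cl)c1)C(=O)COc1ccc2[nH]c(=O)c(S(C)(=O)=O)c(CCc3ccccc3)c2c1`, changes the same amide once more: (3,4-dichlorobenzyl)(methyl)amino in place of anilino on a carbonyl carbon. Among the measured compounds shown here, the aromatic ring thus moves one carbon away from the nitrogen, which also gains a methyl group, so the one relevant step points towards a weaker binder, though it does not directly test this new arrangement. A rise in the number, of a size between the scatter and that measured step, is therefore expected, giving a 2.6-fold higher number from compound 3 to compound 4 (0.42 log units; beyond the scatter). For compound 4 in this assay the estimate is 3500 nM, within 900 nM to 10000 nM.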

Compound 4, inhibition constant: 602 nM
The estimate for compound 4 lay 5.8-fold (0.76 log units) above the measured number, and the stated range ends above it.
By their numbers in this assay, from the lowest: compound 1; then compound 4; then compound 3. At a limit, above all of these: compound 2.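

On this amide, the amide hydrogen is not required for binding in this assay: the (3,4-dichlorobenzyl)(methyl)amino group has no hydrogen-bond donor where anilino has one, yet the change gives a 2.2-fold lower number from compound 3 to compound 4 (0.34 log units; beyond the scatter). Compared with the cyclopropylmethyl amide, the same group gives an at least 16-fold lower number from compound 2 to compound 4 (1.22 log units; beyond the scatter), so among these three compounds, both amides carrying a six-membered aromatic ring have lower numbers, and the ring need not sit directly on the nitrogen. Compound 2 stands at a limit of the measurement, so this larger step gives only a bound and not an exact size: the limit of > 10000 nM in this assay, at which 1 of the 4 values shown sits.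

The step from anilino bundles several changes, namely the added carbon before the ring, the methyl on the nitrogen and the two chlorines, and the compounds shown cannot separate their contributions. A plain benzyl group on the nitrogen, with and without the methyl, would begin to divide them, while a saturated cyclohexylmethyl group would test whether the aromatic ring itself matters.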